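Amide replacement on the shared core; estimate for compound 4

The source may hold more compounds than are shown below. What is called first, only, known or untested is meant among the compounds shown, and "the series" means these compounds.

Measured in an assay on CHO-K1 cells for displacement of a labelled ligand from prostaglandin E2 receptor EP1 subtype (Homo sapiens); on this read-out higher numbers stand for weaker inhibition and lower numbers for stronger inhibition:
compound 1 `Cc1cc(C(=O)NC(C)C)nn1Cc1cc(Cl)ccc1OCc1ccccc1`: 126 nM
compound 2 `Cc1cc(C(=O)Nc2ccccn2)nn1Cc1cc(Cl)ccc1OCc1ccccc1`: 126 nM
compound 3 `Cc1cc(C(=O)NCc2ccncc2)nn1Cc1cc(Cl)ccc1OCc1ccccc1`: 79.4 nM

Compound 3 gives the smallest of the three numbers, but a 1.6-fold lower number from compound 1 to compound 3 (0.20 log units; within the scatter) and a 1.6-fold lower number from compound 2 to compound 3 (0.20 log units; within the scatter) are within the scatter, as is no change at the digits printed from compound 1 to compound 2 (within the scatter), so the three compounds are not separated by this assay. Compound 4 `Cc1cc(NC(=O)C(C)C)nn1Cc1cc(Cl)ccc1OCc1ccccc1` differs from compound 3 in one place: (isopropylcarbonyl)amino in place of ((pyridin-4-yl)methyl)carbamoyl on an aromatic carbon. All three measured steps only exchanged the group on the amide-type nitrogen and stayed within the scatter; none of them touched the carbamoyl group itself, so they bear on this change only loosely. A step of a 3.1-fold higher number from compound 3 to compound 4 (0.50 log units; beyond the scatter) is therefore expected with low confidence. For compound 4 the estimate in this assay is 250 nM, within 60 nM to 1000 nM.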

Compound 4, half-maximal inhibitory concentration: 25.1 nM
Beside the measured number, compound 4's estimate is 10-fold (1.00 log units) above it; the measured number lies below the stated range.
By their numbers in this assay, from the lowest: compound 4; then compounds 3, 1 and 2 (each within the scatter of the next).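

In this assay, the change at this aromatic carbon separates compounds where exchanges on the amide-type nitrogen did not: a 3.2-fold lower number from compound 3 to compound 4 (0.50 log units; beyond the scatter), a 5.0-fold lower number from compound 2 to compound 4 (0.70 log units; beyond the scatter) and a 5.0-fold lower number from compound 1 to compound 4 (0.70 log units; beyond the scatter). The last step keeps the isopropyl group, so that pair differs only in the direction of the amide, with the nitrogen rather than the carbonyl on the ring carbon. Nothing available accounts for this difference. Still open, from the compounds shown here alone, is whether the reversed amide keeps this reading with a longer chain in place of isopropyl. Also open, going by these compounds, is how a plain amine or a sulfonamide would read at this carbon.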